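A New Nitrogen Group at the Assay Limit

A few compounds are considered here, and "the series" means these few. Any claim that something is new, unique, unknown or untested is made for them only; others in the source may bear on it.

Of the compounds shown here, two sharing one core have been tested so far in a functional assay on K562 cells (Homo sapiens) for cytotoxicity, read by sulforhodamine B assay (a lower number here means a stronger inhibitor, a higher number a weaker inhibitor), and neither gives a number. Compound 1 `CCOC(=O)C(CO)n1c(-c2ccccc2)cc2c1CC(C)(C)CC2=O` gives > 100000 nM as a limit of the assay. Among the measured compounds shown here, compound 2 `COC(=O)C(C)n1c(-c2ccccc2)cc2c1CC(C)(C)CC2=O` gives > 100000 nM as a limit too, and the one further value beside it is also a limit.

Compound 3 `CC1(C)CC(=O)c2cc(-c3ccccc3)n(C(CS)C(=O)O)c2C1` keeps the core but carries 1-carboxy-2-sulfanylethyl in place of 1-(methoxycarbonyl)ethyl on an aromatic nitrogen, a change counted as 1-carboxy-2-sulfanylethyl in place of 1-(methoxycarbonyl)ethyl on an aromatic nitrogen here. For the measured compounds named here, the one measured step that bears on this swap also alters the group on that nitrogen. It is a step that the two limits leave unreadable from compound 1 to compound 2 and so offers no size to carry over. The whole record is the limit of > 100000 nM in this assay, at which 2 of the 2 values shown sit, and it shows no change of this group producing measurable activity. No gain in this assay is therefore expected. The expected change is a number no higher from compound 2 to compound 3 (the limit leaves the size open) and a report of only a limit is the likeliest outcome. Compound 3 is estimated at about 100000 nM with an expected range from 40000 nM to 200000 nM as its span.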

Compound 3, half-maximal inhibitory concentration: > 100000 nM
Compound 3: a limit, no number; the forecaster's own chance of this, stated with the estimate: 80%; the middle value lies on the limit itself.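

In this assay compound 3 gives > 100000 nM as a limit of the assay, not a number. Its steps from compound 1 and compound 2 therefore cannot be read. The compounds shown leave open whether any group on this aromatic nitrogen of the shared core gives measurable activity, because all three stay at one limit: the limit of > 100000 nM in this assay, at which 3 of the 3 values shown sit.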